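Swapping a Benzyl for a Fluorophenyl on the Piperazine

The compounds below may be only part of what the source reports. "The series", "measured", "known", "first", "only" and "open" are said of these compounds alone.

Measured so far:
Compound 1 `COc1cc(Cc2cnc(/N=C3\C(=O)N(CN4CCN(Cc5ccccc5)CC4)c4ccc(Cl)cc43)nc2N)cc(OC)c1OC` in an ADME assay on MT4 cells (Homo sapiens) for cytotoxicity, read by MTT assay, with a stated time of 5 days (a higher number here means that more compound is tolerated, a lower number that less compound is tolerated), gives 36.1 ug/mL.
Compound 2 `COc1cc(Cc2cnc(/N=C3\C(=O)N(CN4CCC(C)CC4)c4ccc(Cl)cc43)nc2N)cc(OC)c1OC` in this assay gives 67.4 ug/mL.
Compound 3 `CCCCN(CCCC)CN1C(=O)/C(=N\c2ncc(Cc3cc(OC)c(OC)c(OC)c3)c(N)n2)c2cc(Cl)ccc21` in this assay gives 62.6 ug/mL.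

The three compounds share one core and differ only in the amine attached to the saturated chain carbon bound to the amide-type ring nitrogen. Their numbers all lie within the usual scatter of one another: the gap from compound 1 to compound 3 and the gap from compound 1 to compound 2 are both within it, so no ordering among them can be read with confidence. Among the compounds with values here, the single measured step, a 1.1-fold lower number from compound 2 to compound 3 (0.03 log units; within the scatter), exchanges one amine for another and changes nothing beyond the scatter.

Compound 4 `COc1cc(Cc2cnc(/N=C3\C(=O)N(CN4CCN(c5ccc(F)cc5)CC4)c4ccc(Cl)cc43)nc2N)cc(OC)c1OC` carries 4-fluorophenyl in place of benzyl on an amine nitrogen in a ring. Within the data shown here, no measured step touches this position, so the only guide is that varying the amine has so far left this assay unmoved; the step of a 1.1-fold higher number from compound 1 to compound 4 (0.04 log units; within the scatter) is therefore expected to stay within the scatter. Compound 4 is estimated to give 40 ug/mL, with a range from 18 ug/mL to 90 ug/mL.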

Compound 4, half-maximal cytotoxic concentration: 65.6 ug/mL
Compound 4: middle estimate off by 1.6-fold (0.21 log units), on the low side; the range from low to high includes it.
By their numbers in this assay, from the lowest: compounds 1, 3, 4 and 2 (each within the scatter of the next).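

Within the data shown here, this is the first measured step at the amine nitrogen in the six-membered ring, and in this assay the exchange of benzyl for 4-fluorophenyl gives a 1.8-fold higher number from compound 1 to compound 4 (0.26 log units; within the scatter). Among these compounds, the two groups have the same heavy-atom count, and neither carries hydrogen-bond donors or acceptors, so the step shows that this particular exchange on the ring nitrogen leaves the number within the scatter, as the one earlier step between amines did. No supporting data bear on this result.

The compounds shown leave open whether the fluorine or the change from benzyl to an aryl group counts for more, which plain phenyl on this nitrogen could separate. They also leave open whether a carboxylic acid or a longer chain at this position would move the number beyond the scatter.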